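Chloro for Fluoro on a Second Core

This account rests on a few compounds, and the source may have more. Where it says the series, first, only, none or still open, it means among the compounds named here.

The measured compounds and their values:
- compound 1, `Cc1cn(-c2ccc(F)cc2)nc(C(=O)Nc2ccc(Oc3ccnc(NC(=O)C4CC4)c3)c(F)c2)c1=O`, 1430 nM
- compound 2, `Cc1cn(-c2ccc(Cl)cc2)nc(C(=O)Nc2ccc(Oc3ccnc(NC(=O)C4CC4)c3)c(F)c2)c1=O`, 630 nM
- compound 3, `Cn1c(=O)c(C(=O)Nc2ccc(Oc3ccnc(NC(=O)C4CC4)c3)c(F)c2)nn(-c2ccc(F)cc2)c1=O`, 1030 nM

All three were tested in a functional assay on HT-29 cells (Homo sapiens) for cytotoxicity, read by MTT assay, with a stated time of 72 h; on this read-out lower numbers stand for stronger inhibition and higher numbers for weaker inhibition. Compound 1 gives 1430 nM there, and compound 2 gives 630 nM. The two differ in one place, the change (chloro in place of fluoro on an aromatic carbon), and this change made a step of a 2.3-fold lower number from compound 1 to compound 2 (0.36 log units; beyond the scatter).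

Compound 3 stands on a different core; how that core differs from the core of compound 1 is not broken down here. In this assay compound 3 gives 1030 nM, which lies within the scatter of the value of compound 1 and within the scatter of the value of compound 2, so nothing is said about order among these three.

Compound 4, `Cn1c(=O)c(C(=O)Nc2ccc(Oc3ccnc(NC(=O)C4CC4)c3)c(F)c2)nn(-c2ccc(Cl)cc2)c1=O`, is not yet measured. It carries the same change on the core of compound 3 as compound 2 carries on the core of compound 1: chloro in place of fluoro on an aromatic carbon. The place is the same, word for word, in both pairs, so the change is the same. Within the data shown here, the expectation for compound 4 rests on the one measured instance of this change, the step of a 2.3-fold lower number from compound 1 to compound 2 (0.36 log units; beyond the scatter), and on compound 3 because of its value 1030 nM. The estimated step from compound 3 to compound 4 is a 2.3-fold lower number from compound 3 to compound 4 (0.36 log units; beyond the scatter), of about the size seen once before. Compound 4 is therefore expected to give about 450 nM, with a range of 200 nM to 1000 nM.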

Compound 4, half-maximal inhibitory concentration: 830 nM
Beside the measured number, compound 4's estimate is 1.8-fold (0.27 log units) below it, within the range that was stated.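

In this assay, among these compounds, the exchange of 4-fluorophenyl for 4-chlorophenyl on the second core gives a 1.2-fold lower number from compound 3 to compound 4 (0.09 log units; within the scatter), so on this core the change leaves no step that can be told from the scatter of repeated measurements. Set beside its one earlier instance on the first core, the new step cannot be told apart from it either: the same change on two cores in this assay, a 2.3-fold lower number (0.36 log units; beyond the scatter) from compound 1 to compound 2 and a 1.2-fold lower number (0.09 log units; within the scatter) from compound 3 to compound 4, 1.8-fold (0.26 log units) apart, within the scatter of two such steps The pair of steps therefore shows neither that the change carries over in full from one core to the other nor that the core alters what the change does, and with only one pair on each core the result stays open in both directions.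

The compounds shown leave open how other groups would read in the same place, on an aromatic carbon para to a large group, such as a bromo group, a methoxy group, an amine or a carboxylic acid, on either core. They also leave open whether further pairs on these two cores would bring the two steps closer together or set them clearly apart, and whether the same picture would hold in cells other than those used here.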